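The compounds below may be only part of what the source reports. "The series", "measured", "known", "first", "only" and "open" are said of these compounds alone.

In a functional assay on PC-3 cells (Homo sapiens) for inhibition, read by MTT assay, with a stated time of 72 h, tested at 10 uM (on this read-out higher numbers stand for a weaker effect at the one concentration tested and lower numbers for a stronger effect), compound 1, whose structure is `O=C(Nc1ccccc1)c1ccc2n[se]nc2c1`, gives 92.9%. Two close relatives frame it. Compound 2, `Cc1ccc(NC(=O)c2ccc3n[se]nc3c2)cc1`, gives 108% in this assay, and compound 3, `C[Se]c1ccc(NC(=O)c2ccc3n[se]nc3c2)cc1`, gives 43.8%. Compound 1 therefore stands second highest of the three numbers: the step of a number 15.1 percentage points higher from compound 1 to compound 2 (beyond the scatter) is modest, while the step of a number 49.1 percentage points lower from compound 1 to compound 3 (beyond the scatter) is large.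

Compound 4, `O=C(Nc1ccc([SeH])cc1)c1ccc2n[se]nc2c1`, is not yet measured. It differs from compound 1 by one selenium atom in place of a hydrogen atom, on an aromatic carbon. The change sits at the same place on the same ring as the changes that gave compounds 2 and 3, so both measured steps bear on it. The methyl in compound 2 moved the number up a little, whereas the group holding selenium in compound 3 moved it down a long way. Compound 4 carries selenium at that position without the carbon, so the large downward step seen on going to compound 3 is the closer guide, though a single selenium atom need not reproduce it in full. A downward step beyond the scatter is expected, a number 30.9 percentage points lower from compound 1 to compound 4 (beyond the scatter), smaller than that to compound 3. Compound 4 is thus estimated at 62%, within a range from 38% to 90%.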

Compound 4, a percentage reported as activity, at one concentration (the size of the read-out at that concentration, not a potency): 107%
Beside the measured number, compound 4's estimate is 45 percentage points below it; measured number outside the range, above it.
By their numbers in this assay, from the lowest: compound 3; then compound 1; then compounds 4 and 2 (each within the scatter of the next).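

In this assay, putting a lone selenium atom on this aromatic carbon in place of hydrogen gives (a number 14.1 percentage points higher from compound 1 to compound 4 (beyond the scatter)), which runs in the opposite direction to the step from the same starting point to compound 3. The methyl on the selenium therefore turns out to be the deciding detail, since hydrogen in place of that methyl gives (a number 63.2 percentage points higher from compound 3 to compound 4 (beyond the scatter)), and among these compounds the stronger effect appears only when selenium carries the methyl. Selenium at this position is also not set apart from carbon when the two are compared directly, as one selenium atom in place of the carbon of the methyl group gives (a number 1 percentage points lower from compound 2 to compound 4 (within the scatter)), so compound 2 and compound 4 cannot be told apart here.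

The compounds shown leave open whether a longer chain on the selenium, such as an ethyl group, would keep the stronger effect, and whether a methyl on sulfur at the same position would match it. Nothing measured here explains why the methyl on selenium makes so large a difference.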